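The source may hold more compounds than are shown below. What is called first, only, known or untested is meant among the compounds shown, and "the series" means these compounds.

Measured in a functional assay with Homo sapiens as the target; on this read-out lower numbers stand for stronger inhibition and higher numbers for weaker inhibition:
compound 1 `CC(C)[C@H](NC(=O)COc1cccc2ccccc12)C(=O)N[C@@H](CC(=O)O)C(=O)COc1c(F)cccc1F` gives > 100000 nM (a limit)
compound 2 `CC(C)[C@H](NC(=O)COc1cccc2ccccc12)C(=O)N[C@@H](CC(=O)O)C(=O)COc1c(F)cc(F)cc1F` gives 14900 nM

Among the measured compounds shown here, compound 2 holds the only true number so far, and this assay gives no second number to rank it against. Compound 3 `CC(C)[C@H](NC(=O)COc1cccc2ccccc12)C(=O)N[C@@H](CC(=O)O)C(=O)COc1ccc([N+](=O)[O-])cc1F` is still unmeasured. Its change is 2-fluoro-4-nitrophenyl in place of 2,4,6-trifluorophenyl on an oxygen on a saturated carbon. For the measured compounds named here, one measured step bears on this group: an at least 6.7-fold lower number from compound 1 to compound 2 (0.82 log units; beyond the scatter), with fluoro in place of hydrogen on an aromatic carbon. Going by the values given here, that step rests on a limit, and no measured step involves a nitro group, so it is a loose guide. A slightly higher number is expected, probably within the scatter, as the estimated 1.7-fold higher number from compound 2 to compound 3 (0.22 log units; within the scatter). For compound 3 the estimate is 25000 nM, with an expected range of 6000 nM to 90000 nM.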

Compound 3, half-maximal inhibitory concentration: 15800 nM
Estimate against measurement, compound 3: 1.6-fold (0.20 log units) above; the measured number falls inside the stated range.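

In this assay, 2-fluoro-4-nitrophenyl in place of 2,4,6-trifluorophenyl on an oxygen on a saturated carbon gives a 1.1-fold higher number from compound 2 to compound 3 (0.03 log units; within the scatter), so this assay cannot rank compound 2 and compound 3, and two differently substituted phenyl groups read alike at this place. The second replacement of 2,6-difluorophenyl gives an at least 6.3-fold lower number from compound 1 to compound 3 (0.80 log units; beyond the scatter), which means that two different groups now stand beyond the scatter from compound 1. Compound 1 is a limit and not a number, which leaves both steps from it as bounds on size: the limit of > 100000 nM in this assay, at which 1 of the 3 values shown sits.

Compound 3 differs from compound 2 in its nitro group and in its fluoro count together, and the compounds shown do not separate the two. Also open, from the compounds shown here alone, is how an amine or a nitrile in place of the nitro group would read in this assay.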